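A Sulfonamide Chain in Place of a Carbamate

The source may hold more compounds than are shown below. What is called first, only, known or untested is meant among the compounds shown, and "the series" means these compounds.

Measured so far:
compound 1 `CC(C)(C)OC(=O)NCCCCNC(=O)CN1CN(c2ccccc2)C2(CCN(C(=O)c3ccc(C(C)(C)C)cc3)CC2)C1=O` — "not determined" (no result reported)
compound 2 `CCc1nn(CC)c(C2CCN(C(=O)CN3CN(c4ccccc4)C4(CCN(C(=O)c5ccc(C6CCCCC6)cc5)CC4)C3=O)CC2)c1C` — "not determined" (no result reported)
compound 3 `CC1CCCN(C(=O)CN2CN(c3ccccc3)C3(CCN(C(=O)c4ccc(C5CCCCC5)cc4)CC3)C2=O)C1` — 3600 nM

Of the three compounds carrying the shared core, only compound 3 has a number in an assay on HEK293 cells for displacement of a labelled ligand from NPC1-like intracellular cholesterol transporter 1 (Homo sapiens); a lower number here means a stronger inhibitor, a higher number a weaker inhibitor. Compound 1 stands without a value: neither it nor compound 2 returned a result, so the only anchor for this series is compound 3, which in this assay gives 3600 nM. Compound 1 therefore cannot be placed above or below any other compound on the numbers shown.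

The step under consideration leads from compound 1 to compound 4 `CC(C)(C)c1ccc(C(=O)N2CCC3(CC2)C(=O)N(CC(=O)NCCCCCNS(C)(=O)=O)CN3c2ccccc2)cc1`. The change is (methanesulfonamido)methyl in place of (tert-butoxycarbonyl)amino on a saturated chain carbon, four bonds along the chain from an amide-type nitrogen. The rest of the molecule, including the core and the amide-type nitrogen from which the chain runs, is kept.

Within the data shown here, no pair of measured compounds differing in one place exists here. Nothing tells how this assay responds to such an exchange on the chain. No direction can be read off; a change of modest size in either direction, or none beyond the scatter, is all that can reasonably be expected in this assay.

Among the measured compounds shown here, on the one value known for the series, compound 4 is expected to give about 3500 nM, with a plausible range from 500 nM to 25000 nM.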

Compound 4, half-maximal inhibitory concentration: 5500 nM
Beside the measured number, compound 4's estimate is 1.6-fold (0.20 log units) below it, within the range that was stated.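

In this assay compound 4 gives 5500 nM, but compound 1 has no number to set against it, so no step can be read between compound 1 and compound 4. The compounds shown leave open how exchanging (tert-butoxycarbonyl)amino for (methanesulfonamido)methyl on the chain affects the result. Nothing shown bears on the value of compound 4.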